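A few compounds are considered here, and "the series" means these few. Any claim that something is new, unique, unknown or untested is made for them only; others in the source may bear on it.

Three measured compounds of the series, compound 1 `CN1CCN(Cc2sc(NC(=O)c3cccnc3)nc2-c2cccnc2)CC1`, compound 2 `CC(C)N(C)Cc1sc(NC(=O)c2cccnc2)nc1-c1cccnc1` and compound 3 `CN(C)Cc1sc(NC(=O)c2cccnc2)nc1-c1cccnc1`, share one core and differ only in the group on a saturated chain carbon bound to an aromatic carbon. In an assay on isolated protein for inhibition of Rho-associated protein kinase 2 (Homo sapiens), read by ELISA, with a stated time of 30 min, tested at 10 uM, in the presence of a further agent that is not named here (a lower number here means less inhibition, a higher number more inhibition at the concentration tested (going by the name of the read-out)), compound 1 gives 32.1%, compound 2 gives 38.1% and compound 3 gives 33.9%. The steps between them, a number 6 percentage points higher from compound 1 to compound 2 (within the scatter), a number 1.8 percentage points higher from compound 1 to compound 3 (within the scatter) and a number 4.2 percentage points lower from compound 2 to compound 3 (within the scatter), all lie within the scatter, so the three numbers cannot be told apart. Compound 3 stands second highest of the three, with compound 1 nearest and compound 2 furthest, both within the scatter.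

Compound 4 `O=C(Nc1nc(-c2cccnc2)c(CN2CCCCC2)s1)c1cccnc1` is not yet measured. From compound 3 it differs in one place: piperidin-1-yl in place of dimethylamino on a saturated chain carbon bound to an aromatic carbon. For the measured compounds named here, the steps that bear on this change are the ones that exchange the group at the same place, a number 1.8 percentage points higher from compound 1 to compound 3 (within the scatter) and a number 6 percentage points higher from compound 1 to compound 2 (within the scatter), together with a number 4.2 percentage points lower from compound 2 to compound 3 (within the scatter) on the amine nitrogen; none of them moved the number beyond the scatter. A step of the same kind is therefore expected here, a number 1.1 percentage points higher from compound 3 to compound 4 (within the scatter), with no clear direction. Compound 4 is estimated at 35%, with a range from 22% to 48%.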

Compound 4, a percentage reported as inhibition, at one concentration (the size of the read-out at that concentration, not a potency): 28.5%
Compound 4: middle estimate off by 6.5 percentage points, on the high side; the range from low to high includes it.
By their numbers in this assay, from the lowest: compounds 4, 1, 3 and 2 (each within the scatter of the next).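

In this assay the series now includes piperidin-1-yl on a saturated chain carbon bound to an aromatic carbon, and replacing dimethylamino with this ring, which takes the group from 3 heavy atoms to 6 heavy atoms, gives a number 5.4 percentage points lower from compound 3 to compound 4 (within the scatter) and so no readable change. The other two exchanges at this place, a number 9.6 percentage points lower from compound 2 to compound 4 (within the scatter) and a number 3.6 percentage points lower from compound 1 to compound 4 (within the scatter), stay inside the scatter as well, so the open-chain amines and both ring amines shown cannot be told apart at this place, and the four compounds have no order in this assay. Nothing at hand explains why the numbers stay together.

Morpholin-4-yl, a primary amine, a carboxylic acid or a longer chain between the core and the amine could still move the number beyond the scatter at this place, and the compounds shown do not test any of them. All four numbers also come from one tested concentration in this assay and so leave open whether potencies in a full concentration series would differ among these amines.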